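The source may report more compounds than this note shows. Statements on the series, on what has been measured and on what is new or still open speak of the compounds shown alone.

Measured compounds in an assay on isolated protein for inhibition of Dihydrofolate reductase (Homo sapiens), read by spectrophotometry, using NADPH, with stated times of 5 s and 6 min, tested at 5 uM; a higher number here means a stronger effect of the compound at the concentration tested, a lower number a weaker effect:
Compound 1 `NC1=NC2(CCSCC2)N(OCCCOc2ccc(Cl)c(Cl)c2)C(N)=N1` gives 88.4%.
Compound 3 `NC1=NC2(CCOCC2)N(OCCCOc2ccccc2Br)C(N)=N1` gives 83.8%.
Compound 2 `NC1=NC2(CCOCC2)N(OCCCOc2cc(Cl)c(Cl)cc2Cl)C(N)=N1` reaches only a limit of the assay, > 90%.

Among the measured compounds shown here, compound 1 and compound 3 are the only two with numbers rather than limits, and they lie within the scatter of each other; compound 2 sits at the limit (the limit of > 90% in this assay, at which 1 of the 3 values shown sits). For the measured compounds named here, the one measured step, a number at least 6.2 percentage points lower from compound 2 to compound 3 (that floor lies within the scatter), has a floor within the scatter and involves a different pair of aryl groups. Compound 4 `NC1=NC2(CCSCC2)N(OCCCOc2ccccc2Cl)C(N)=N1` differs from compound 1 by 2-chlorophenyl in place of 3,4-dichlorophenyl on an oxygen on a saturated carbon. Going by the values given here, no measured step shares this exact change, so compound 4 is expected to stay close to compound 1, with at most a small loss, a number 8.4 percentage points lower from compound 1 to compound 4 (within the scatter). Compound 4 is estimated at 80%, in the range 65% to 90%.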

Compound 4, a percentage reported as inhibition, at one concentration (the size of the read-out at that concentration, not a potency): 86.3%
The estimate for compound 4 lay 6.3 percentage points below the measured number; measured number inside the range.
By their numbers in this assay, from the lowest: compounds 3, 4 and 1 (each within the scatter of the next). At a limit, above all of these: compound 2.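

In this assay, the exchange of 3,4-dichlorophenyl for 2-chlorophenyl, on an oxygen on a saturated carbon, gives a number 2.1 percentage points lower from compound 1 to compound 4 (within the scatter). It is the only step shown on the core of compound 1, and it shows that this position takes an aryl group with one chlorine fewer without a readable change at the concentration tested. Going by these compounds, whether an amine or a carboxylic acid in place of the phenyl group would keep the read-out stays open. Compound 2 remains a limit, not a number, which leaves its place among the others open: the limit of > 90% in this assay, at which 1 of the 4 values shown sits.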